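Replacing the Cyanoethenyl Group of Compound 2

The source may report more compounds than this note shows. Statements on the series, on what has been measured and on what is new or still open speak of the compounds shown alone.

In an ADME assay on HEK293 cells (Homo sapiens) for cytotoxicity, with a stated time of 72 h (a higher number here means that more compound is needed for the effect, a lower number that less compound is needed), compound 1 (`C=C[C@@](C)(/C=C/c1ccc(O)cc1)CC/C=C/C(=O)OCC`) gives > 36600 nM and this is only a limit. Compound 2 (`C=C[C@@](C)(/C=C/c1ccc(O)cc1)CC/C=C/C#N`) gives > 36600 nM and this too is only a limit. For the measured compounds named here, the one measured step is a step that the two limits leave unreadable from compound 1 to compound 2 so it offers no size to carry forward. Compound 3 (`C=C[C@@](C)(/C=C/c1ccc(O)cc1)CC/C=C(\C)CO`) follows from compound 2 by 2-(hydroxymethyl)prop-1-en-1-yl in place of 2-cyanoethenyl on a saturated chain carbon, three bonds along the chain from two double-bonded chain carbons and keeps the rest of the structure. Compound 1 and compound 2 share the limit of > 36600 nM in this assay, at which 2 of the 2 values shown sit, so no step beyond the scatter is expected in this assay and no direction can be named. The expected change is a step that the limit leaves unreadable from compound 2 to compound 3 in this estimate. For compound 3 the estimated value is 40000 nM with an expected range (15000 nM to 80000 nM) and quite possibly only a limit.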

Compound 3, half-maximal effective concentration: > 36600 nM
Compound 3: no number, only a limit; the forecaster's own chance of this, stated with the estimate: 75%; the middle value is on the limit's open side.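

No new step can be read among compound 1, compound 2 and compound 3, because all three stop at the same limit: the limit of > 36600 nM in this assay, at which 3 of the 3 values shown sit.

The compounds shown leave open whether swapping these side chains shifts the result in this assay at all.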